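Removing a methyl from compound 1: what to expect

The compounds below may be only part of what the source reports. "The series", "measured", "known", "first", "only" and "open" are said of these compounds alone.

The study measures growth inhibition with a functional assay on PSN1 cells (Homo sapiens) for inhibition; a higher number here means a weaker inhibitor of growth, a lower number a stronger inhibitor of growth. Compound 1 `C/C=C/C=C/C(=O)C[C@H](CCO)OC` gives 50000 nM in this assay. Two further compounds have been measured alongside it. Compound 2 `C/C=C/C=C/C(=O)CC(CCO)OCC[C@H](O)CC(=O)/C=C/C=C/C` gives 29000 nM, and compound 3 `C/C=C/CCC(=O)C[C@@H](O)CCO` gives 54000 nM. All three numbers lie within the usual scatter of one another, so no order among them can be read from this assay; compound 1 simply sits among them.

The next compound, compound 4 `C/C=C/C=C/C(=O)C[C@@H](O)CCO`, differs from compound 1 in one place: hydrogen in place of methyl on an oxygen on a saturated carbon. Cut one bond further out, the change reads as methoxy to hydroxy.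

For the measured compounds named here, no step between measured compounds tells how this change acts here. The three measured values cluster so closely that the account expects no shift beyond the scatter, so the step of a 1.1-fold lower number from compound 1 to compound 4 (0.05 log units; within the scatter) is expected to be small. Compound 4 is therefore estimated at 45000 nM, within a range of 20000 nM to 100000 nM.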

Compound 4, concentration for 50% growth inhibition: 54000 nM
Estimate against measurement, compound 4: 1.2-fold (0.08 log units) below; the measured number falls inside the stated range.
By their numbers in this assay, from the lowest: compounds 2, 1, 3 and 4 (each within the scatter of the next).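

In this assay, for the compounds shown here, the step of a 1.1-fold higher number from compound 1 to compound 4 (0.03 log units; within the scatter) gives the first direct reading of this position, since no earlier pair of compounds differed in one place. Hydrogen in place of methyl on an oxygen on a saturated carbon, or methoxy to hydroxy when cut one bond further out, leaves the number within the scatter, so the methyl can go without a shift this assay can resolve. Nothing measured here bears on why the step is so small.

From the compounds shown here alone, whether an amine in place of the hydroxy, or a longer chain on the same oxygen, would move the number stays open. So does the question of whether this change would stay as small on a core that gives a much lower number.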